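The source may hold more compounds than are shown below. What is called first, only, known or untested is meant among the compounds shown, and "the series" means these compounds.

Measured in a functional assay on MCF7 cells (Homo sapiens) for antiproliferative activity, read by MTT assay, with a stated time of 72 h; on this read-out lower numbers stand for stronger inhibition and higher numbers for weaker inhibition:
- compound 1 `CC1=CC[C@H]2[C@H](CC[C@]2(C)O)C(C)(C)[C@@H]1CC[C@H]1[C@]2(C)CC[C@H](OC(=O)c3ccccc3)C(C)(C)O[C@H]2CC[C@@]1(C)O`: 21000 nM
- compound 2 `CC1=CC[C@H]2[C@@H]1CC=C(C)[C@@H](CC[C@H]1[C@]3(C)CC[C@H](OC(=O)c4ccc(Cl)cc4)C(C)(C)O[C@H]3CC[C@@]1(C)O)C2(C)C`: 22000 nM
- compound 3 `CC1=CC[C@H]2[C@@H]1CC=C(C)[C@@H](CC[C@H]1[C@]3(C)CC[C@H](OCc4ccccc4)C(C)(C)O[C@H]3CC[C@@]1(C)O)C2(C)C`: > 50000 nM, a limit of the assay and not a number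

Only compound 1 and compound 2 have true numbers. These lie within the scatter of each other, so compound 1 cannot be ranked against compound 2.

Compound 4 `CC1=CC[C@H]2[C@H](CC[C@]2(C)O)C(C)(C)[C@@H]1CC[C@H]1[C@]2(C)CC[C@H](OC(=O)NS(=O)(=O)c3ccc(C)cc3)C(C)(C)O[C@H]2CC[C@@]1(C)O` keeps the core of compound 1 and alters one group: ((4-methylphenyl)sulfonyl)amino in place of phenyl on a carbonyl carbon. Going by the values given here, no measured step makes this exact change. The closest is an at least 2.2-fold higher number from compound 2 to compound 3 (0.35 log units; beyond the scatter), in which the carbonyl is lost as benzyl replaces (4-chlorophenyl)carbonyl. Going by these compounds, that step ends at a limit (the limit of > 50000 nM in this assay, at which 1 of the 3 values shown sits), so its true size is unknown. Compound 4 keeps the carbonyl that compound 3 lacks, so a large step seems unlikely, although the new group is much larger than phenyl. The expected step in this assay is a 1.2-fold higher number from compound 1 to compound 4 (0.08 log units; within the scatter), which would not go beyond the scatter. The estimate for compound 4 is 25000 nM, with an expected range from 10000 nM to 50000 nM.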

Compound 4, half-maximal inhibitory concentration: > 50000 nM
Compound 4 was reported as a limit; the forecaster's own chance of this, stated with the estimate: 20%; middle value at least 2.0-fold (0.30 log units) away from the limit.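

In this assay, ((4-methylphenyl)sulfonyl)amino in place of phenyl on the carbonyl carbon gives an at least 2.3-fold higher number from compound 1 to compound 4 (0.37 log units; beyond the scatter), so the group on this carbonyl matters even when the carbonyl itself stays. Going by these compounds alone, the only earlier step in this part of the molecule, an at least 2.2-fold higher number from compound 2 to compound 3 (0.35 log units; beyond the scatter), removed the carbonyl and so could not show this. Compound 4 gives > 50000 nM, which is a limit of the assay and not a number, so the true size of the step stays unknown, and the read-out now stops at this same limit more than once: the limit of > 50000 nM in this assay, at which 2 of the 4 values shown sit.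

The compounds shown do not separate the sulfonyl, the amino hydrogen and the 4-methylphenyl ring as the part that counts. A plain amino group or a methyl on the carbonyl carbon would show whether a small group fares better here than the larger ones.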